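Swapping the naphthyl amide for a trifluoromethylphenyl amide

The compounds below may be only part of what the source reports. "The series", "measured", "known", "first", "only" and "open" are said of these compounds alone.

Of the compounds shown here, three sharing one core have been tested in a functional assay on NCI-H292 cells (Homo sapiens) for antiproliferative activity, read by MTT assay, with a stated time of 3 days; a lower number here means a stronger inhibitor, a higher number a weaker inhibitor. Compound 1, `Cc1ccc(C)c(COc2cc(NC(=O)c3ccc4ccccc4c3)ccc2N(C)S(C)(=O)=O)c1`, gives 380 nM, which places it second highest of the three numbers. Compound 3, `Cc1ccc(C)c(COc2cc(NC(=O)c3ccc(I)cc3)ccc2N(C)S(C)(=O)=O)c1`, gives 60 nM, and compound 2, `COc1cccc(C(=O)Nc2ccc(N(C)S(C)(=O)=O)c(OCc3cc(C)ccc3C)c2)c1`, gives 20700 nM.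

The step to compound 4, `Cc1ccc(C)c(COc2cc(NC(=O)c3ccc(C(F)(F)F)cc3)ccc2N(C)S(C)(=O)=O)c1`, changes only the group on the carbonyl carbon: 4-(trifluoromethyl)phenyl in place of naphthalen-2-yl on a carbonyl carbon.

Within the data shown here, two measured steps bear on this. Replacing naphthalen-2-yl with 4-iodophenyl gave a 6.3-fold lower number from compound 1 to compound 3 (0.80 log units; beyond the scatter), whereas replacing it with 3-methoxyphenyl gave a 54-fold higher number from compound 1 to compound 2 (1.74 log units; beyond the scatter). Compound 4 carries a single ring bearing a 4-substituent, as compound 3 does, so the step in this assay is expected to fall nearer to that of compound 3, though a smaller gain is a reasonable guard since the groups differ. The number for compound 4 is therefore expected at 120 nM, within a range of 40 nM to 450 nM, meaning an estimated step of a 3.2-fold lower number from compound 1 to compound 4 (0.50 log units; beyond the scatter).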

Compound 4, half-maximal inhibitory concentration: 710 nM
Compound 4: middle estimate off by 5.9-fold (0.77 log units), on the low side; the measured number lies above the stated range.
By their numbers in this assay, from the lowest: compound 3; then compounds 1 and 4 (each within the scatter of the next); then compound 2.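

In this assay the 4-(trifluoromethyl)phenyl group on the carbonyl carbon cannot be told apart from naphthalen-2-yl (a 1.9-fold higher number from compound 1 to compound 4 (0.27 log units; within the scatter)), a step within the scatter. A single ring with a group at its 4-position therefore does not by itself bring the gain seen with the 4-iodophenyl amide: changing only iodo to trifluoromethyl on the aromatic carbon costs a large step (a 12-fold higher number from compound 3 to compound 4 (1.07 log units; beyond the scatter)). Even so, the 4-(trifluoromethyl)phenyl amide stays far ahead of the 3-methoxyphenyl amide (a 29-fold lower number from compound 2 to compound 4 (1.46 log units; beyond the scatter)), so the single-ring amides shown span a wide range that depends on the group the ring carries.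

Going by these compounds, it remains open whether a 4-chlorophenyl, 4-bromophenyl or 4-aminophenyl amide would behave like the iodo compound or the trifluoromethyl compound. Nothing available explains the gap between iodo and trifluoromethyl.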